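The source may report more compounds than this note shows. Statements on the series, on what has been measured and on what is new or still open speak of the compounds shown alone.

In a functional assay on 786-0 cells (Homo sapiens) for inhibition, read by sulforhodamine B assay, with a stated time of 48 h (a higher number here means a weaker inhibitor of growth, a lower number a stronger inhibitor of growth), three compounds sharing one core have been measured. Compound 1 (`CC1(/C=C/c2ccccc2)C=CC(=O)O1`) gives 170000 nM in this test, compound 3 (`CC1(/C=C/c2cccc(O)c2)C=CC(=O)O1`) gives 196000 nM in this test, and compound 2 (`COc1ccc(/C=C/C2(C)C=CC(=O)O2)cc1OC`) gives 22900 nM in this test. Compound 3 therefore stands level with compound 1 within the scatter, and compound 2 lies clearly below both.

Compound 4 (`COc1cccc(/C=C/C2(C)C=CC(=O)O2)c1`) departs from compound 3 by one change, (methyl in place of hydrogen on an oxygen on an aromatic ring), methyl in place of hydrogen on an oxygen on an aromatic ring, that is, hydroxy to methoxy. Among the compounds with values here, the one measured step nearby is a 1.2-fold higher number from compound 1 to compound 3 (0.06 log units; within the scatter) for hydroxy in place of hydrogen, and it lies within the scatter. Within the data shown here, no measured step tests the methoxy swap directly. Among the measured compounds shown here, the only hint comes from compound 2, which carries methoxy and reads 22900 nM in this test, though it differs in more than one place.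

A moderate step of a 2.5-fold lower number from compound 3 to compound 4 (0.39 log units; beyond the scatter) is therefore expected in this assay, towards a lower number, with real doubt about its size. For compound 4 the estimated value is 80000 nM, with an expected range from 28000 nM to 190000 nM in this test.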

Compound 4, concentration for total growth inhibition: 70000 nM
Beside the measured number, compound 4's estimate is 1.1-fold (0.06 log units) above it, within the range that was stated.
By their numbers in this assay, from the lowest: compound 2; then compound 4; then compounds 1 and 3 (each within the scatter of the next).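

In this assay, methyl in place of hydrogen on the oxygen on the aromatic ring gives a 2.8-fold lower number from compound 3 to compound 4 (0.45 log units; beyond the scatter), the first sign that this oxygen responds to what it carries. Set against the parent compound, methoxy gives a 2.4-fold lower number from compound 1 to compound 4 (0.39 log units; beyond the scatter), whereas hydroxy gave a 1.2-fold higher number from compound 1 to compound 3 (0.06 log units; within the scatter), so the two groups part ways here even though both replace hydrogen on an aromatic carbon. Methoxy count also tracks the number in this small set, with hydrogen in place of methoxy giving a 3.1-fold higher number from compound 2 to compound 4 (0.49 log units; beyond the scatter).

The compounds shown leave open whether a longer chain on that oxygen, such as ethoxy, or an amine or a carboxylic acid on the aromatic carbon would continue this trend. Nothing available explains why methoxy and hydroxy differ in this test.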